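Enantiomer of the tightest binder in a uracil series

The source may report more compounds than this note shows. Statements on the series, on what has been measured and on what is new or still open speak of the compounds shown alone.

Measured compounds:
- compound 1, `COc1cccc(-c2c(C)n(Cc3c(F)cccc3F)c(=O)n(C[C@@H](N)CCc3ccccc3)c2=O)c1F`: 965 nM
- compound 2, `COc1cccc(-c2c(C)n(Cc3c(F)cccc3F)c(=O)n(C[C@H](NC(C)C)C3CCCCC3)c2=O)c1F`: 23 nM
- compound 3, `COc1cccc(-c2c(C)n(Cc3c(F)cccc3F)c(=O)n(C[C@H](N)CC(C)C)c2=O)c1F`: 6.4 nM

In an assay on HEK293 cells for binding affinity to Gonadotropin-releasing hormone receptor (Homo sapiens), read by radioligand binding (on this read-out lower numbers stand for stronger inhibition and higher numbers for weaker inhibition), compound 3 stands lowest of the three numbers: a 3.6-fold lower number from compound 2 to compound 3 (0.56 log units; beyond the scatter) and a 150-fold lower number from compound 1 to compound 3 (2.18 log units; beyond the scatter) both lie beyond the scatter. Compound 4, `COc1cccc(-c2c(C)n(Cc3c(F)cccc3F)c(=O)n(C[C@@H](N)CC(C)C)c2=O)c1F`, is its mirror image at one centre: the two compounds have the same atoms and bonds and differ only in configuration as drawn: 1 of 1 stereo elements differ; a stereocentre at a saturated chain carbon is drawn R in compound 3 and S in compound 4. For the measured compounds named here, none of the three measured steps keeps the atoms and changes only the configuration; each swaps a side group, so no step bears directly on this change, and the direction cannot be read from the data. The estimate for compound 4 is therefore uncertain, with a change of a 6.3-fold higher number from compound 3 to compound 4 (0.80 log units; beyond the scatter) expected towards a higher number. Compound 4 is expected at 40 nM, within 6 nM to 300 nM.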

Compound 4, inhibition constant: 39 nM
The estimate for compound 4 lay 1.0-fold (0.01 log units) above the measured number; low and high end bracket the measured number.
By their numbers in this assay, from the lowest: compound 3; then compounds 2 and 4 (each within the scatter of the next); then compound 1.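

In this assay, a 6.1-fold higher number from compound 3 to compound 4 (0.78 log units; beyond the scatter) gives the first direct read on configuration at this saturated chain carbon: the form drawn R has the lower number, and the gap belongs to this one centre alone because nothing else changes: the fact that compounds 3 and 4 differ only in the configuration as drawn. Even when drawn S, isopropyl in place of benzyl still leaves a 25-fold lower number from compound 1 to compound 4 (1.39 log units; beyond the scatter). The swap of side group in a 1.7-fold higher number from compound 2 to compound 4 (0.23 log units; within the scatter) separates nothing.

As far as these compounds go, whether the R form keeps its lead with other side groups remains open. So does how a hydroxyl group in place of the amine would read at either configuration.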